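The source may report more compounds than this note shows. Statements on the series, on what has been measured and on what is new or still open speak of the compounds shown alone.

Working notes on a small set of phenol amides bearing a triazole, all assessed in a functional assay on RAW264.7 cells (Mus musculus) for inhibition, read by Griess assay, with a stated time of 20 h; a higher number here means a weaker inhibitor, a lower number a stronger inhibitor. Compound 1 `CCCNC(=O)c1cc(-n2cc(-c3cccc(Cl)c3)nn2)ccc1O` gives only a limit of the assay, > 20000 nM. Compound 2 `CCCNC(=O)c1cc(-n2cc(-c3cc(F)cc(F)c3)nn2)ccc1O` likewise gives only a limit, > 20000 nM. Compound 3 `CCCNC(=O)c1ccc(-n2cc(-c3cccc(Cl)c3)nn2)cc1O` also returns only a limit, > 20000 nM. The change from compound 1 to compound 2 is 3,5-difluorophenyl in place of 3-chlorophenyl on an aromatic carbon; the step that the two limits leave unreadable from compound 1 to compound 2 is unreadable, both values being limits. The difference between the core of compound 1 and the core of compound 3 is not broken down here. Compound 4 `CCCNC(=O)c1ccc(-n2cc(-c3cc(F)cc(F)c3)nn2)cc1O` carries the same change on the core of compound 3, (3,5-difluorophenyl in place of 3-chlorophenyl on an aromatic carbon). For compound 4 the expected step is a step that the limit leaves unreadable from compound 3 to compound 4, an expectation resting on (the limit of > 20000 nM in this assay, at which 3 of the 3 values shown sit). Compound 4 is thus estimated at 30000 nM, with an expected range from 10000 nM to 100000 nM.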

Compound 4, half-maximal inhibitory concentration: > 20000 nM
Compound 4: no number, only a limit; the forecaster's own chance of this, stated with the estimate: 85%; the middle value does not contradict the limit.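

Compound 3 and compound 4 both give only a limit, so no step between them can be read: the limit of > 20000 nM in this assay, at which 4 of the 4 values shown sit.

Whether 3,5-difluorophenyl and 3-chlorophenyl, or the two cores, differ in inhibition stays open, as no compound shown gives a number.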